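Swapping the aryl group on the amide nitrogen

A few compounds are considered here, and "the series" means these few. Any claim that something is new, unique, unknown or untested is made for them only; others in the source may bear on it.

Compound 1 `O=C(CN1CCN(c2nnc(Cc3ccncc3)c3ccccc23)CC1)Nc1cccc(Br)c1`: 1350 nM
Compound 2 `COc1ccc(NC(=O)CN2CCN(c3nnc(Cc4ccccc4)c4ccccc34)CC2)cc1OC`: 145000 nM

The two compounds were tested in a functional assay on HT-29 cells (Homo sapiens) for cytotoxicity, read by MTT assay, with a stated time of 72 h; a lower number here means a stronger inhibitor, a higher number a weaker inhibitor. Compound 2 has the higher number of the two, at 145000 nM, and so is the weaker inhibitor. Its distance from compound 1, at 1350 nM, lies well beyond the usual scatter.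

Compound 3 `O=C(CN1CCN(c2nnc(Cc3ccccc3)c3ccccc23)CC1)Nc1ccc(F)c(Cl)c1` comes from compound 2 by a single change: 3-chloro-4-fluorophenyl in place of 3,4-dimethoxyphenyl on an amide-type nitrogen.

Among the measured compounds shown here, no measured pair isolates this change, so the forecast is uncertain. Compound 1 also lacks the 3,4-dimethoxyphenyl and gives 1350 nM, which suggests a drop beyond the scatter, although compound 1 differs from compound 2 in more than one place. The expected shift is a 24-fold lower number from compound 2 to compound 3 (1.38 log units; beyond the scatter). For compound 3 the estimated value is 6000 nM, with an expected range of 1000 nM to 35000 nM.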

Compound 3, half-maximal inhibitory concentration: 13300 nM
The estimate for compound 3 lay 2.2-fold (0.35 log units) below the measured number, within the range that was stated.
By their numbers in this assay, from the lowest: compound 1; then compound 3; then compound 2.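

In this assay the aryl group on the amide-type nitrogen now has a measured effect of its own: 3-chloro-4-fluorophenyl in place of 3,4-dimethoxyphenyl gives an 11-fold lower number from compound 2 to compound 3 (1.04 log units; beyond the scatter) with the rest of the molecule unchanged. The earlier gap between compound 1 and compound 2 could not be tied to this position, as those two differ in more than one place, whereas this pair shows that the position alone can move the number beyond the scatter. Nothing measured here says why the number moves.

As far as these compounds go, the change swaps both methoxy groups for chlorine and fluorine in one step, so it remains open which of these atoms or groups carries the shift. A cyclohexyl group on this nitrogen, or a phenyl ring bearing only a chlorine, would begin to separate these possibilities.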